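Changing the Pendant Aryl Group on a Shared Kinase Binder

The source may hold more compounds than are shown below. What is called first, only, known or untested is meant among the compounds shown, and "the series" means these compounds.

Compound 1, `CCCS(=O)(=O)Nc1ccc(F)c(C(=O)c2n[nH]c3ncc(-c4ccc(C)c(C)c4)cc23)c1F`: 20%
Compound 2, `CCCS(=O)(=O)Nc1ccc(F)c(C(=O)c2n[nH]c3ncc(-c4ccc(Cl)c(C(F)(F)F)c4)cc23)c1F`: 15%

In an assay for binding affinity to dual specificity mitogen-activated protein kinase kinase 4 (Homo sapiens), read by KINOMEscan, tested at 100 nM (on this read-out lower numbers stand for a stronger effect and higher numbers for a weaker effect at the one concentration tested), compound 1 gives 20% and compound 2 gives 15%. Compound 2 thus has the lowest of the two numbers, with compound 1 nearest to it, the two lying within the scatter of each other. Compound 3, `CCCS(=O)(=O)Nc1ccc(F)c(C(=O)c2n[nH]c3ncc(-c4ccc(OC)cc4Cl)cc23)c1F`, differs from compound 2 by 2-chloro-4-methoxyphenyl in place of 4-chloro-3-(trifluoromethyl)phenyl on an aromatic carbon. Among the compounds with values here, the only measured step, a number 5 percentage points lower from compound 1 to compound 2 (within the scatter), also exchanged the aryl group at this position and stayed within the scatter, so no step beyond the scatter is expected here either; the expected step is a number 7 percentage points higher from compound 2 to compound 3 (within the scatter). Compound 3 is therefore estimated at 22%, in the range 8% to 45%.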

Compound 3, a percentage reported as activity, at one concentration (the size of the read-out at that concentration, not a potency): 5.3%
Beside the measured number, compound 3's estimate is 16.7 percentage points above it; the whole stated range lies above it.
By their numbers in this assay, from the lowest: compounds 3, 2 and 1 (each within the scatter of the next, the first and the last beyond it).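

In this assay the aryl group on this aromatic carbon now gives its first change beyond the scatter, with 2-chloro-4-methoxyphenyl in place of 3,4-dimethylphenyl giving a number 14.7 percentage points lower from compound 1 to compound 3 (beyond the scatter). Replacing 4-chloro-3-(trifluoromethyl)phenyl with the same group gives only a number 9.7 percentage points lower from compound 2 to compound 3 (within the scatter), so the gain is clear against one earlier aryl group and not the other. Nothing available explains either step.

The compounds shown leave open how the chlorine and the methoxy each contribute, since they appear only together in compound 3. They also leave open whether an aryl group bearing an amine or a carboxylic acid would be accepted at this position.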